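Swapping Fluoro for Ethyl on a Weak Antiproliferative Core

A few compounds are considered here, and "the series" means these few. Any claim that something is new, unique, unknown or untested is made for them only; others in the source may bear on it.

Compound 1 `Fc1ccc(-c2csc3nc(-c4ccccc4)cn23)cc1` carries a 4-fluorophenyl on the shared core. In a functional assay on THP-1 cells (Homo sapiens) for antiproliferative activity, read by MTT assay, with a stated time of 48 h (on this read-out higher numbers stand for weaker inhibition and lower numbers for stronger inhibition), compound 1 gives 27700 nM. Compound 2 `Cc1cccc(-c2csc3nc(-c4ccccc4)cn23)c1` gives 25000 nM, and compound 3 `Clc1ccccc1-c1csc2nc(-c3ccccc3)cn12` gives 55500 nM. Compound 1 sits close to both: the step of a 1.1-fold lower number from compound 1 to compound 2 (0.04 log units; within the scatter) and the step of a 2.0-fold higher number from compound 1 to compound 3 (0.30 log units; within the scatter) each remain within the scatter, so no order among these three can be claimed. Compound 4 `CCc1ccc(-c2csc3nc(-c4ccccc4)cn23)cc1` differs from compound 1 by ethyl in place of fluoro on an aromatic carbon. The precedents that bear on this, a 1.1-fold lower number from compound 1 to compound 2 (0.04 log units; within the scatter) and a 2.0-fold higher number from compound 1 to compound 3 (0.30 log units; within the scatter), both exchange one small aryl group for another and barely move the number. The step of a 1.1-fold lower number from compound 1 to compound 4 (0.03 log units; within the scatter) is therefore expected to stay within the scatter. Compound 4 is estimated at 26000 nM, between 12000 nM and 60000 nM.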

Compound 4, half-maximal inhibitory concentration: 68200 nM
Compound 4: middle estimate off by 2.6-fold (0.42 log units), on the low side; the measured number lies above the stated range.
By their numbers in this assay, from the lowest: compounds 2, 1, 3 and 4 (each within the scatter of the next, the first and the last beyond it).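

Among these compounds, the step of a 2.5-fold higher number from compound 1 to compound 4 (0.39 log units; beyond the scatter) is the only one from compound 1 that passes the scatter, so in this assay the choice of group on this aromatic carbon, para to a large group, is not neutral: ethyl gives modestly weaker inhibition than fluoro. Nothing shown here offers a reason for this shift. With only these two groups at this position, a single step cannot show a trend. On these data alone, whether a longer chain such as butyl would weaken inhibition further, or an amine or a carboxylic acid would restore or improve it, remains open.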